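The source may report more compounds than this note shows. Statements on the series, on what has been measured and on what is new or still open speak of the compounds shown alone.

Compound 1 `CC1CCc2nc(N)nc(O)c2C1` gives 4.26 in an assay for inhibition of Dihydrofolate reductase (Homo sapiens) (a lower number here means a less potent compound, a higher number a more potent compound, by a factor of ten per unit of this negative logarithm), and holds the lowest of the three numbers in hand. Compound 3 `Nc1ncnc2ccc([S+]([O-])c3ccc4ccccc4c3)cc12` gives 4.82 in this assay, the nearest number, higher than that of compound 1 beyond the scatter. Compound 2 `Nc1nc(S)c2cc(S(=O)(=O)c3ccc4ccccc4c3)ccc2n1` gives 7.6 in this assay, the furthest number, again higher beyond the scatter. Compound 4 `Nc1nc(O)c2c(n1)CCCC2` differs from compound 1 in one place: hydrogen in place of methyl on a saturated ring carbon. For the measured compounds named here, no measured pair shows this change, so its direction is open. The removal of the methyl is expected to move the number only a little, probably not beyond the scatter, with a slight lean downward. The estimated step is a number 0.16 log units lower from compound 1 to compound 4 (within the scatter). Compound 4 is therefore expected near 4.1, between 3.6 and 4.7.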

Compound 4, logarithm of the reciprocal of the active concentration, log(1/C): 3.96
For compound 4 the middle estimate is 0.14 log units above the measured one; low and high end bracket the measured number.
By their numbers in this assay, from the lowest: compounds 4 and 1 (each within the scatter of the next); then compound 3; then compound 2.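

For the compounds shown here, replacing methyl with hydrogen on the saturated ring carbon gives a number 0.30 log units lower from compound 1 to compound 4 (within the scatter) in this assay and provides the first one-place pair. At this position, the methyl and the hydrogen cannot be told apart in this assay, so the methyl shows no measurable contribution here. No measurement on hand bears on the reason for this result.

On these data alone, whether an amine, a carboxylic acid or a longer chain on this carbon would move the number remains open. As far as these compounds go, it is also open whether the same change would behave alike on a different core.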